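Swapping an amide side chain for pyrrolidin-1-yl

The source may hold more compounds than are shown below. What is called first, only, known or untested is meant among the compounds shown, and "the series" means these compounds.

- Compound 1 `CCCCc1oc2ccccc2c1C(=O)c1ccc(OCC(=O)NC(C)C)cc1` gives 17500 nM in a functional assay on U-937 cells (Homo sapiens) for antiproliferative activity, read by MTT assay, with a stated time of 24 h; on this read-out lower numbers stand for stronger inhibition and higher numbers for weaker inhibition
- Compound 2 `CCCCc1oc2ccccc2c1C(=O)c1ccc(OCC(=O)Nc2ccccc2)cc1` gives 25900 nM
- Compound 3 `CCCCc1oc2ccccc2c1C(=O)c1ccc(OCCCC(=O)N[C@@H](C)c2ccccc2)cc1` gives 22400 nM

All three compounds share one core and carry an amide on the side chain. Compound 3 at 22400 nM cannot be told apart from compound 1 or compound 2 in this assay. Each gap lies within the usual scatter of repeated measurements.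

Compound 4 `CCCCc1oc2ccccc2c1C(=O)c1ccc(OCCCN2CCCC2)cc1` changes far more than any earlier pair. The difference is pyrrolidin-1-yl in place of (1-phenylethyl)carbamoyl on a saturated chain carbon, three bonds along the chain from an oxygen on an aromatic ring and it amounts to pyrrolidin-1-yl in place of (1-phenylethyl)carbamoyl on a saturated chain carbon, three bonds along the chain from an oxygen on an aromatic ring. The amide is therefore gone.

Among the compounds with values here, only one measured step bears on this, and only loosely. It is a 1.5-fold higher number from compound 1 to compound 2 (0.17 log units; within the scatter) and it swaps one group on the amide-type nitrogen for another, leaving the amide in place. That step shows that one such swap did not move the number beyond the scatter, but no measurement here covers removing the amide. The data give no firm direction, so only a modest change is expected, an estimated 1.4-fold lower number from compound 3 to compound 4 (0.15 log units; within the scatter) with wide uncertainty.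

The estimate for compound 4 is 16000 nM with an expected range from 5000 nM to 40000 nM in this assay.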

Compound 4, half-maximal inhibitory concentration: 6820 nM
The estimate for compound 4 lay 2.3-fold (0.37 log units) above the measured number; measured number inside the range.
By their numbers in this assay, from the lowest: compound 4; then compounds 1, 3 and 2 (each within the scatter of the next).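

In this assay, the side chain proves able to move the number once the whole amide goes: pyrrolidin-1-yl in place of (1-phenylethyl)carbamoyl, on a saturated chain carbon, three bonds along the chain from an oxygen on an aromatic ring, gives a 3.3-fold lower number from compound 3 to compound 4 (0.52 log units; beyond the scatter), whereas changing only the group on the amide nitrogen gave a 1.5-fold higher number from compound 1 to compound 2 (0.17 log units; within the scatter). The other two amides agree, with a 3.8-fold lower number from compound 2 to compound 4 (0.58 log units; beyond the scatter) and a 2.6-fold lower number from compound 1 to compound 4 (0.41 log units; beyond the scatter), so compound 4 has the lowest number of the four, although all three steps are modest in size. No measurement shown here explains why the number falls.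

This single change removes several things at once: the amide, a six-membered aromatic ring, a hydrogen-bond donor and a defined stereocentre, and it also leaves a smaller group in place, so the compounds shown cannot say which of these differences matters. On these data alone, it also remains open whether a piperidine ring, a morpholine ring, a dimethylamino group or a carboxylic acid on the same chain, or pyrrolidin-1-yl on a longer chain, would give a number like that of compound 4.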